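A few compounds are considered here, and "the series" means these few. Any claim that something is new, unique, unknown or untested is made for them only; others in the source may bear on it.

Compound 1 `COc1cc2c(Oc3ccc(NC(=O)C4(c5nnc(-c6ccc(F)cc6)o5)CC4)cc3F)ccnc2cc1OCCCN1CCCC1` gives 2340 nM in a functional assay on PC-3 cells (Homo sapiens) for antiproliferative activity, read by MTT assay, with a stated time of 72 h (a higher number here means a weaker inhibitor, a lower number a stronger inhibitor), the second highest of the three numbers at hand. Compound 2 `COc1cc2c(Oc3ccc(NC(=O)c4cc(-c5ccc(F)cc5)on4)cc3)ccnc2cc1OCCCN1CCC(C)CC1` gives 2040 nM in this assay, a number within the scatter of compound 1, while compound 3 `COc1cc2nccc(Oc3ccc(NC(=O)c4ncc(-c5ccc(F)cc5)o4)cc3)c2cc1OC` gives 21900 nM, a gap from compound 1 that lies beyond the scatter. Compound 4 `COc1cc2c(Oc3ccc(NC(=O)C4(c5nnc(-c6ccc(F)cc6)o5)CC4)cc3F)ccnc2cc1OCCCN1CCC(C)CC1` has not been measured; it differs from compound 1 by 4-methylpiperidin-1-yl in place of pyrrolidin-1-yl on a saturated chain carbon, three bonds along the chain from an oxygen on an aromatic ring. For the measured compounds named here, no measured pair isolates this change. Compound 2 already carries the entering ring, on a different amide portion, and its value sits close to that of compound 1. On that basis the change is expected to bring a 1.1-fold lower number from compound 1 to compound 4 (0.05 log units; within the scatter), in no direction beyond the scatter. Compound 4 is therefore estimated at 2100 nM, between 900 nM and 4800 nM.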

Compound 4, half-maximal inhibitory concentration: 2180 nM
For compound 4 the middle estimate is 1.0-fold (0.02 log units) below the measured one, within the range that was stated.
By their numbers in this assay, from the lowest: compounds 2, 4 and 1 (each within the scatter of the next); then compound 3.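

In this assay, for the compounds shown here, putting 4-methylpiperidin-1-yl in place of pyrrolidin-1-yl on a saturated chain carbon, three bonds along the chain from an oxygen on an aromatic ring, gives a 1.1-fold lower number from compound 1 to compound 4 (0.03 log units; within the scatter) and so isolates this change for the first time. With the rest of the structure held fixed, the six-membered ring with its methyl group and the five-membered ring cannot be told apart here. Nothing at hand gives a reason for this. On these data alone, whether morpholin-4-yl, a dimethylamino group or a 2-(pyrrolidin-1-yl)ethyl chain would also fall within the scatter stays open.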